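From Methoxyphenylsulfanyl to Fluorophenoxy on a Shared Core

A few compounds are considered here, and "the series" means these few. Any claim that something is new, unique, unknown or untested is made for them only; others in the source may bear on it.

Of the compounds shown here, three sharing one core have been measured in a functional assay on TK-10 cells (Homo sapiens) for inhibition, read by sulforhodamine B assay, with a stated time of 48 h; on this read-out lower numbers stand for stronger inhibition of growth and higher numbers for weaker inhibition of growth. Compound 1, `Nc1cc(N)c2nc(-c3ccccc3)c(NCc3ccc(Cl)c(Cl)c3)nc2c1`, gives 30200 nM. Compound 2, `CCOC(=O)[C@H](CCC(=O)O)NC(=O)c1ccc(Oc2nc3cc(N)cc(N)c3nc2-c2ccccc2)cc1`, gives 17800 nM. Compound 3, `COc1ccc(Sc2nc3cc(N)cc(N)c3nc2-c2ccccc2)cc1`, gives 30200 nM. On these numbers compound 3 stands level with compound 1 at the digits shown, and the two together are the highest of the three; compound 2 gives a lower number, but the gap between compound 2 and compound 3 is within the scatter, so no order among the three can be read from this assay.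

Compound 4, `Nc1cc(N)c2nc(-c3ccccc3)c(Oc3ccc(F)cc3)nc2c1`, is not yet measured. It differs from compound 3 in one place: 4-fluorophenoxy in place of (4-methoxyphenyl)sulfanyl on an aromatic carbon. Among the measured compounds shown here, no pair of measured compounds that differ in one place is available, so the size of this step cannot be read off from the data. What is known is that compound 2, which also carries an oxygen-linked aryl group at this position of the core, gives 17800 nM, and that this does not part from compound 3 beyond the scatter. Compound 4 is therefore expected to sit close to compound 3, with a step of a 1.2-fold lower number from compound 3 to compound 4 (0.08 log units; within the scatter) that is expected to stay within the scatter. The estimate for compound 4 in this assay is 25000 nM, with a range from 8000 nM to 80000 nM.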

Compound 4, concentration for total growth inhibition: 32400 nM
Estimate against measurement, compound 4: 1.3-fold (0.11 log units) below; the measured number falls inside the stated range.
By their numbers in this assay, from the lowest: compounds 2, 1, 3 and 4 (each within the scatter of the next).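

In this assay, among the compounds shown here, the exchange of (4-methoxyphenyl)sulfanyl for 4-fluorophenoxy on this aromatic carbon gives a 1.1-fold higher number from compound 3 to compound 4 (0.03 log units; within the scatter) and so provides the first step at this place that can be read directly, which the earlier compounds could not supply. The step changes the linking atom and the group on the outer ring at once, and the read-out still stays within the scatter, so this particular double exchange leaves the level of growth inhibition where it was. Nothing measured alongside these compounds bears on why the two numbers stay level.

For the compounds shown here, the single step cannot show whether the linking atom and the outer ring substituent each make no difference or whether their contributions offset one another, and (4-fluorophenyl)sulfanyl and 4-methoxyphenoxy at this place would separate the two. It also leaves open whether any group here can move the number beyond the scatter, for example a phenoxy ring carrying a carboxylic acid or an amine, or a longer chain between the core and the ring.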